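Aryl Amide Cytotoxicity: Bromo Replaced by Acetylphenyl

The source may report more compounds than this note shows. Statements on the series, on what has been measured and on what is new or still open speak of the compounds shown alone.

Compound 1 `CC(C)(C)NC(=O)CCc1cccc2c1B(O)OC2` gives > 100000 nM in an ADME assay on WI-38 cells (Homo sapiens) for cytotoxicity, read by MTT assay, with a stated time of 72 h (on this read-out lower numbers stand for stronger inhibition and higher numbers for weaker inhibition), which is a limit of the assay.
Compound 2 `O=C(CCc1cccc2c1B(O)OC2)Nc1cccc(Br)c1` gives 20000 nM in this assay.
Compound 3 `Cc1ccc(NC(=O)CCc2cccc3c2B(O)OC3)cc1Br` gives 15000 nM in this assay.

Among the numbers, compound 2 holds the highest, with compound 3 within the scatter of it. Compound 4 `CC(=O)c1cccc(-c2cccc(NC(=O)CCc3cccc4c3B(O)OC4)c2)c1` carries 3-acetylphenyl in place of bromo on an aromatic carbon. Among the compounds with values here, two measured steps bear on this. The step of an at least 5.0-fold lower number from compound 1 to compound 2 (0.69 log units; beyond the scatter) shows that a 3-bromophenyl on the amide nitrogen gave a clearly lower number, whereas a 1.3-fold lower number from compound 2 to compound 3 (0.12 log units; within the scatter) shows a ring change that stayed within the scatter. Since the new group is a further aromatic ring, a modest lowering of the number is expected for compound 4, estimated as a 2.0-fold lower number from compound 2 to compound 4 (0.30 log units; within the scatter). Compound 4 is therefore expected to give about 10000 nM, with a range from 3000 nM to 40000 nM.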

Compound 4, half-maximal inhibitory concentration: 2200 nM
Estimate against measurement, compound 4: 4.5-fold (0.66 log units) above; the measured number lies below the stated range.
By their numbers in this assay, from the lowest: compound 4; then compounds 3 and 2 (each within the scatter of the next). At a limit, above all of these: compound 1.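

In this assay, within the data shown here, the aromatic carbon that carried bromo takes the much larger 3-acetylphenyl, and the number falls: a 9.1-fold lower number from compound 2 to compound 4 (0.96 log units; beyond the scatter) marks the first change on this aromatic ring that lies beyond the scatter. The earlier ring change, methyl in place of hydrogen, stayed within it. Nothing measured here accounts for this step.

As far as these compounds go, it remains open whether the added ring alone carries the step or the acetyl is needed. From the compounds shown here alone, it is also open how a plain phenyl, or a ring bearing an amine or a carboxylic acid, would read at this position.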